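A few compounds are considered here, and "the series" means these few. Any claim that something is new, unique, unknown or untested is made for them only; others in the source may bear on it.

Compound 1 `CC(C)c1cccc(C(C)C)c1NC(=O)NC1=NN(Cc2ccccc2)NN1` and compound 2 `CCCCN1NN=C(NC(=O)Nc2c(C(C)C)cccc2C(C)C)N1` share a core that differs only in the group carried on the ring nitrogen. In an assay on microsomes from intestine for inhibition of acyl-CoA:cholesterol acyltransferase (Oryctolagus cuniculus) (on this read-out higher numbers stand for weaker inhibition and lower numbers for stronger inhibition), compound 1 gives 370 nM, the highest of the two numbers shown, while compound 2 gives 92 nM, a gap that lies beyond the usual scatter. For the measured compounds named here, no step between measured compounds is given for this pair, so only what the two values show can be said of it.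

Compound 3 `CC(C)c1cccc(C(C)C)c1NC(=O)NC1=NN(CCCCCCCCCCCO)NN1` has not yet been measured in this assay. It differs from compound 1 by 10-hydroxydecyl in place of phenyl on a saturated chain carbon bound to an amine nitrogen in a ring.

Because compound 2 with its butyl chain reaches 92 nM, a modest move toward a lower number is expected for compound 3, of about a 2.5-fold lower number from compound 1 to compound 3 (0.39 log units; beyond the scatter). In this assay compound 3 is estimated at 150 nM, within a range from 50 nM to 500 nM.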

Compound 3, half-maximal inhibitory concentration: 32 nM
Compound 3: middle estimate off by 4.7-fold (0.67 log units), on the high side, and the stated range ends above it.
By their numbers in this assay, from the lowest: compound 3; then compound 2; then compound 1.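

The step of a 12-fold lower number from compound 1 to compound 3 (1.06 log units; beyond the scatter) in this assay shows that this position, on a saturated chain carbon bound to an amine nitrogen in a ring, accepts a long open chain ending in a hydroxyl group, and that phenyl is not needed there for inhibition. The earlier pair showed only the printed values of compound 1 and compound 2, and with compound 2 at 92 nM and compound 3 at 32 nM, the new chain gives the lower number of those two. No measurement here explains the size of this step.

The compounds shown leave open whether the chain length or the hydroxyl group carries the change, which a plain decyl group would begin to separate. They also leave open how a carboxylic acid or an amine in place of the hydroxyl would read in this assay.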